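Amino for hydrogen on the core of compound 2

A few compounds are considered here, and "the series" means these few. Any claim that something is new, unique, unknown or untested is made for them only; others in the source may bear on it.

Three compounds of the series have numbers. Compound 1 `ClCc1ccccc1Cn1cnc2c(Cl)nc(Cl)nc21` gives 1770 nM in a functional assay on OVCAR-4 cells (Homo sapiens) for cytotoxicity, read by sulforhodamine B assay, with a stated time of 48 h; on this read-out higher numbers stand for weaker inhibition of growth and lower numbers for stronger inhibition of growth; compound 2 `ClCc1ccccc1Cn1cnc2c(Cl)ncnc21` gives 3380 nM; compound 3 `ClCc1ccc(Cn2cnc3c(Cl)nc(Cl)nc32)cc1` gives 4900 nM. Compound 2 stands second highest of the three, with compound 3 nearest and compound 1 furthest, both within the scatter of it, so no order among the three can be drawn.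

Compound 4 `Nc1nc(Cl)c2ncn(Cc3ccccc3CCl)c2n1` is not yet measured. It differs from compound 2 by amino in place of hydrogen on an aromatic carbon, between two ring nitrogen atoms, meta to a chloro group.

Among the measured compounds shown here, the only measured step at this carbon is a 1.9-fold higher number from compound 1 to compound 2 (0.28 log units; within the scatter), chloro against hydrogen, and it stayed within the scatter. For the measured compounds named here, no step shows amino at any position. The expectation for compound 4 is therefore a step of a 1.1-fold lower number from compound 2 to compound 4 (0.05 log units; within the scatter), none beyond the scatter, in no firm direction. Compound 4 is estimated at 3000 nM, with a range from 900 nM to 10000 nM.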

Compound 4, concentration for 50% growth inhibition: 2460 nM
Compound 4: middle estimate off by 1.2-fold (0.09 log units), on the high side; low and high end bracket the measured number.
By their numbers in this assay, from the lowest: compounds 1, 4, 2 and 3 (each within the scatter of the next, the first and the last beyond it).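

Amino at this carbon, between two ring nitrogen atoms, gives the first reading of a group other than hydrogen or chloro here, and a 1.4-fold lower number from compound 2 to compound 4 (0.14 log units; within the scatter) stays within the scatter. Set against chloro on the same carbon, a 1.4-fold higher number from compound 1 to compound 4 (0.14 log units; within the scatter) also stays within the scatter, so hydrogen, chloro and amino at this position fall in no order. Nothing measured bears on why these three groups read alike.

As far as these compounds go, whether a methoxy group, a dimethylamino group or a carboxylic acid on this carbon would step beyond the scatter remains open. Also open, from the compounds shown here alone, is whether amino here would read the same with the side chain of compound 3, which so far carries only chloro at this carbon.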